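Swapping methyl for chloro on an aromatic carbon

The source may hold more compounds than are shown below. What is called first, only, known or untested is meant among the compounds shown, and "the series" means these compounds.

In a functional assay on CCRF-CEM cells (Homo sapiens) for antiproliferative activity, read by trypan blue exclusion, with a stated time of 72 h (on this read-out higher numbers stand for weaker inhibition and lower numbers for stronger inhibition), compound 3 `Cc1ccc(C(=O)NC(N)=O)cc1NC(=O)C(C)Cl` gives > 20000 nM, which is a limit of the assay and not a number. This is the limit of > 20000 nM in this assay, at which 1 of the 3 values shown sits, so compound 3 has no exact place on the scale.

Compound 4 `CC(Cl)C(=O)Nc1cc(C(=O)NC(N)=O)ccc1Cl` differs from compound 3 at one place: chloro in place of methyl on an aromatic carbon.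

Going by the values given here, no measured step covers this change directly. The only one, a 3.4-fold lower number from compound 1 to compound 2 (0.53 log units; beyond the scatter), puts hydrogen in place of methyl on the chain carbon bound to a bromine atom and a carbonyl carbon, so it shows a modest effect elsewhere in the molecule. In this assay, compound 1 `CC(Br)C(=O)Nc1cc(C(=O)NC(N)=O)ccc1Cl` gives 9800 nM and compound 2 `NC(=O)NC(=O)c1ccc(Cl)c(NC(=O)CBr)c1` gives 2910 nM.

Compound 1 is the closest guide, as it carries the same chloro, though its chain has bromine where compound 4 has chlorine. Compound 1 gives 9800 nM, which suggests that compound 4 may reach a measurable number, so a modest move towards stronger inhibition is expected. That expected move is estimated as an at least 1.4-fold lower number from compound 3 to compound 4 (0.15 log units; that floor lies within the scatter), and its true size stays uncertain.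

For compound 4 the estimated value is 14000 nM, with an expected range of 6000 nM to 30000 nM.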

Compound 4, half-maximal inhibitory concentration: > 20000 nM
Compound 4: no number, only a limit (the forecaster's own chance of this, stated with the estimate: 35%); at least 1.4-fold (0.15 log units) between middle value and limit.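

In this assay, the swap of methyl for chloro on this aromatic carbon cannot be read, because compound 3 and compound 4 both end at a limit of the assay and not at a number: the limit of > 20000 nM in this assay, at which 2 of the 4 values shown sit. What is new is that chloro at this place, para to the carbamoylcarbamoyl group, does not on its own bring a compound with the ((1-chloroethyl)carbonyl)amino group onto the measurable part of the scale. The side chain gives the clearer signal, as 1-chloroethyl in place of bromomethyl on the carbonyl carbon brings an at least 6.8-fold higher number from compound 2 to compound 4 (0.83 log units; beyond the scatter), whereas chloro in place of bromo on the chain brings an at least 2.0-fold higher number from compound 1 to compound 4 (0.30 log units; that floor lies within the scatter), and that floor alone does not settle the order of the two compounds.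

From the compounds shown here alone, it remains open how an amine or a methoxy group on the same aromatic carbon would compare with methyl and chloro. Also open, going by these compounds, is how a chloromethyl group on the carbonyl carbon would behave, since that group would separate the change of halogen from the loss of the chain methyl.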